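From phenyl to 4-chlorophenyl: compound 3 to compound 4

The source may hold more compounds than are shown below. What is called first, only, known or untested is meant among the compounds shown, and "the series" means these compounds.

Measured in an ADME assay on MCF-10A cells (Homo sapiens) for cytotoxicity, read by MTT assay, with a stated time of 48 h; on this read-out higher numbers stand for weaker inhibition and lower numbers for stronger inhibition:
Compound 1 `COc1ccc(-c2nnc(COc3ccc(C#N)cc3OC)o2)cc1`: > 100000 nM (a limit)
Compound 2 `COc1cc(C#N)ccc1OCc1nnc(-c2ccc(Cl)cc2)o1`: 89500 nM
Compound 3 `N#Cc1ccc(OCc2nnc(-c3ccccc3)o2)cc1F`: > 100000 nM (a limit)

Compound 3 gives > 100000 nM in this assay, which is a limit and not a number. This is the limit of > 100000 nM in this assay, at which 2 of the 3 values shown sit. Compound 4 `N#Cc1ccc(OCc2nnc(-c3ccc(Cl)cc3)o2)cc1F` differs from it by chloro in place of hydrogen on an aromatic carbon, which turns phenyl into 4-chlorophenyl.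

Going by the values given here, one measured step bears on this change: an at least 1.1-fold lower number from compound 1 to compound 2 (0.04 log units; that floor lies within the scatter). That step also places chloro on an aromatic carbon, though in place of methoxy, and it starts from a limit. Compound 2, which carries the same 4-chlorophenyl, gives 89500 nM. A number close to that of compound 2 therefore seems likely, with a further reading at the limit just as possible. The expected step is an at least 1.1-fold lower number from compound 3 to compound 4 (0.04 log units; that floor lies within the scatter), and no change beyond the scatter is expected. For compound 4 the estimated value is 90000 nM, with an expected range from 50000 nM to 160000 nM.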

Compound 4, half-maximal inhibitory concentration: > 100000 nM
Compound 4 was reported as a limit; the forecaster's own chance of this, stated with the estimate: 45%; middle value at least 1.1-fold (0.04 log units) away from the limit.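

In this assay compound 3 gives > 100000 nM, which is a limit. Compound 4 gives > 100000 nM, also a limit, so no step can be read between compound 3 and compound 4. The compounds shown leave open whether chloro in place of hydrogen changes the read-out here at all.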